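A few compounds are considered here, and "the series" means these few. Any claim that something is new, unique, unknown or untested is made for them only; others in the source may bear on it.

Compound 1 `COc1ccc2c(c1)c(/C=N\NC(=O)c1c[nH]c3ccc(Br)cc13)cn2Cc1ccc(Cl)cc1`: 5000 nM
Compound 2 `O=C(N/N=C\c1cn(Cc2ccc(Cl)cc2)c2ccc(Br)cc12)c1c[nH]c2ccccc12`: 1000 nM

In a functional assay on MDA-MB-231 cells (Homo sapiens) for cytotoxicity (a lower number here means a stronger inhibitor, a higher number a weaker inhibitor), compound 1 gives 5000 nM, while compound 2 gives 1000 nM. Compound 2 therefore stands at the lowest of the two numbers, and its gap to compound 1 lies beyond the usual scatter, so compound 2 is the stronger of the two measured.

Compound 3 `O=C(N/N=C\c1cn(Cc2ccc(Cl)cc2)c2ccccc12)c1c[nH]c2ccccc12` has not been measured. It differs from compound 2 in one place: hydrogen in place of bromo on an aromatic carbon. Among the measured compounds shown here, no measured pair shows this same change, so the size of the step can only be guessed. Given that compound 2 already sits at the low end, the change is expected to cost some strength rather than add to it, in a step of modest size that may not clear the scatter. The expected step of a 2.5-fold higher number from compound 2 to compound 3 (0.40 log units; beyond the scatter) is a small rise. Compound 3 is estimated at 2500 nM, with a range from 800 nM to 8000 nM.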

Compound 3, half-maximal inhibitory concentration: 66400 nM
Compound 3: the middle estimate sits 27-fold (1.42 log units) below what was measured, and the stated range ends below it.
By their numbers in this assay, from the lowest: compound 2; then compound 1; then compound 3.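

In this assay, hydrogen in place of bromo on this aromatic carbon, meta to a fused ring and para to a fused ring, produces a 66-fold higher number from compound 2 to compound 3 (1.82 log units; beyond the scatter) and so marks a large step beyond the scatter. This shows that the position is far from indifferent: a single bromine here accounts for a large share of the strength seen in this pair. The data shown offer no measurement that would explain the size of this step.

From the compounds shown here alone, only bromo and hydrogen can be compared directly at this carbon, so it remains open whether the strength depends on bromine itself. Going by these compounds, how a chloro, a methyl or a nitrile group would behave in the same place also remains unknown.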